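Furan-2-yl to pyridin-4-yl: a single step in the series

The source may report more compounds than this note shows. Statements on the series, on what has been measured and on what is new or still open speak of the compounds shown alone.

Measured so far in an in vitro assay on BTI-TN-5B1-4 cells for inhibition of Amine oxidase [flavin-containing] A (Homo sapiens), read by Amplex Red, with a stated time of 15 min, tested at 100 uM; a higher number here means more inhibition at the concentration tested (going by the name of the read-out), a lower number less inhibition:
compound 1 `N#Cc1ccc(-c2csc(N/N=C\c3ccco3)n2)cc1`: 40%
compound 2 `C/C(=N/Nc1nc(-c2ccc(C#N)cc2)cs1)c1ccco1`: 40%
compound 3 `C/C(=N/Nc1nc(-c2ccc(C#N)cc2)cs1)c1ccccc1`: 40%

Compound 1 sits level with compounds 2 and 3 at the digits printed; the nearest to it is compound 2 and the furthest compound 3, and in neither case does the gap exceed the scatter. All three therefore read as one level in this assay.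

Among the measured compounds shown here, the only step that changes the aryl group on the carbon with a double bond to nitrogen is no change at the digits printed from compound 2 to compound 3 (within the scatter). That step, phenyl in place of furan-2-yl, left the read-out unchanged within the scatter.

Compound 4 `N#Cc1ccc(-c2csc(N/N=C\c3ccncc3)n2)cc1` is not yet measured. Its change from compound 1 is pyridin-4-yl in place of furan-2-yl on a carbon with a double bond to nitrogen. This bears a resemblance to the measured step, since in both cases furan-2-yl leaves and a six-membered aromatic ring enters at the same place. On that basis no movement beyond the scatter is expected: compound 4 is expected at no change at the digits printed from compound 1 to compound 4 (within the scatter) relative to compound 1. The estimate for compound 4 in this assay is 40%, with a range from 25% to 55%.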

Compound 4, a percentage reported as inhibition, at one concentration (the size of the read-out at that concentration, not a potency): "not active" (no number reported)
For compound 4 the study gives words and no number, and the estimate cannot be compared.
By their numbers in this assay, from the lowest: compounds 1, 2 and 3 (each within the scatter of the next).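

Among the compounds shown here, compound 4 is reported as "not active" (no number reported), so no step from compound 1 to compound 4 can be read, and its place relative to compounds 1, 2 and 3 stays unfixed. The compounds shown leave open how far pyridin-4-yl in place of furan-2-yl moves the read-out from compound 1 at 40%. No evidence bears on this result.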